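The compounds below may be only part of what the source reports. "The series", "measured", "known", "first", "only" and "open" are said of these compounds alone.

Of the compounds shown here, two share one core and have been tested in a functional assay on L1210 cells (Mus musculus) for cytotoxicity; a higher number here means a weaker inhibitor, a lower number a stronger inhibitor. Compound 1, `Cc1c2cc[n+](C)cc2c(C)c2c3c([nH]c12)C=CC(=O)[C@@]31O[C@@H]2[C@H](O1)[C@@H](COP(=O)(O)O)O[C@H]2n1cnc2c(N)ncnc21`, carries a phosphate on its sugar and an adenine base. Compound 2, `Cc1c2cc[n+](C)cc2c(C)c2c3c([nH]c12)C=CC(=O)[C@@]31O[C@@H]2[C@H](O1)[C@@H](CO)O[C@H]2n1cnc2c(O)nc(N)nc21`, carries a free hydroxymethyl group and a guanine base. In this assay compound 1 reaches only a limit of the assay, > 0.8 uM. In this assay, within the data shown here, compound 2 gives 0.8 uM, which is the only true number among the results so far. Because the limit of > 0.8 uM in this assay, at which 1 of the 2 values shown sits, marks the result of compound 1 as a limit rather than a number, compound 2 cannot be ranked against compound 1 beyond noting that the two results sit at the same figure.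

Compound 3, `Cc1c2cc[n+](C)cc2c(C)c2c3c([nH]c12)C=CC(=O)[C@@]31O[C@@H]2[C@H](O1)[C@@H](COP(=O)(O)O)O[C@H]2n1cnc2c(O)nc(N)nc21`, is not yet measured. It differs from compound 2 by a group of 4 heavy atoms (3 oxygen, 1 phosphorus; no ring) in place of a hydrogen atom, on an oxygen on a saturated carbon, so it combines the phosphate of compound 1 with the guanine base of compound 2. Among the measured compounds shown here, compound 3 is expected to be somewhat weaker, because the limit of > 0.8 uM in this assay, at which 1 of the 2 values shown sits, shows the only phosphate-bearing compound reaching just a limit. The expected step from compound 2 to compound 3 in this assay is a 3.1-fold higher number from compound 2 to compound 3 (0.49 log units; beyond the scatter). The estimate for compound 3 is 2.5 uM, within a range of 0.8 uM to 10 uM.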

Compound 3, concentration for 50% inhibition: > 1 uM
Compound 3: only a limit was reported; the forecaster's own chance of this, stated with the estimate: 50%; the middle value is on the limit's open side.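

In this assay compound 3 gives a limit rather than a number: the limit of > 1 uM in this assay, at which 1 of the 3 values shown sits. Placing the phosphate group on the oxygen of the hydroxymethyl group while keeping the guanine base gives the first comparison in which only this one place changes, and the readable step is an at least 1.2-fold higher number from compound 2 to compound 3 (0.09 log units; that floor lies within the scatter), so the data do not establish that this change weakens the compound, although the true step could be larger. Compound 1 and compound 3 both carry the phosphate group and both end at limits, so the step between them, which would have shown the effect of exchanging adenine for guanine, cannot be read.

The compounds shown leave open how large the phosphate step really is, since its size is bounded on one side only. They also leave open how a methyl ether or a sulfate would read on the same oxygen, and how the adenine base would read with a free hydroxymethyl group.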